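The source may report more compounds than this note shows. Statements on the series, on what has been measured and on what is new or still open speak of the compounds shown alone.

Working notes on the chain-ester series in a functional assay on A549 cells (Homo sapiens) for cytotoxicity, read by MTT assay, with a stated time of 24 h, tested at 80 uM; a higher number here means a weaker effect of the compound at the concentration tested, a lower number a stronger effect. Three compounds with a shared core differ only in the length of the saturated chain on the ester oxygen: compound 1 `CCCCCCCCCCCCCCOC(=O)CCC(=O)N1CCN(CCCOc2cc3c(Nc4ccc(F)c(Cl)c4)ncnc3cc2OC)CC1` gives 77.2%, compound 2 `CCCCCCCCCCCCCCCOC(=O)CCC(=O)N1CCN(CCCOc2cc3c(Nc4ccc(F)c(Cl)c4)ncnc3cc2OC)CC1` gives 81.1%, and compound 3 `CCCCCCCCCCCCCCCCOC(=O)CCC(=O)N1CCN(CCCOc2cc3c(Nc4ccc(F)c(Cl)c4)ncnc3cc2OC)CC1` gives 74.3%. Compound 3 stands among the other two rather than apart from them: the step of a number 2.9 percentage points lower from compound 1 to compound 3 (within the scatter) and the step of a number 6.8 percentage points lower from compound 2 to compound 3 (within the scatter) both lie within the scatter, as does a number 3.9 percentage points higher from compound 1 to compound 2 (within the scatter).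

The next member is compound 4 `CCCCCCCCCCCCCCCCCCCCOC(=O)CCC(=O)N1CCN(CCCOc2cc3c(Nc4ccc(F)c(Cl)c4)ncnc3cc2OC)CC1`. Relative to compound 3 the change is butyl in place of hydrogen on a saturated chain carbon, ten or more bonds along the chain from an oxygen next to a carbonyl group. The three measured steps all bear on this, each being a lengthening of the same chain at the same place, and none of them moved this assay beyond the scatter. The lengthening to compound 4 is larger than any measured step, but nothing shown suggests a direction. The expectation is therefore a step of a number 2.7 percentage points higher from compound 3 to compound 4 (within the scatter) in this assay, that is, none beyond the scatter, and compound 4 is estimated at 77%, with a range from 65% to 89%.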

Compound 4, a percentage reported as activity, at one concentration (the size of the read-out at that concentration, not a potency): 85.2%
Beside the measured number, compound 4's estimate is 8.2 percentage points below it, and the stated range covers the measured number.
By their numbers in this assay, from the lowest: compounds 3, 1, 2 and 4 (each within the scatter of the next, the first and the last beyond it).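

In this assay, among these compounds, the butyl in place of hydrogen gives the first step to pass the scatter, a number 10.9 percentage points higher from compound 3 to compound 4 (beyond the scatter), so lengthening at this saturated chain carbon can shift the read-out, though only modestly. The shift separates a single pair: pentyl gives a number 4.1 percentage points higher from compound 2 to compound 4 (within the scatter) and hexyl gives a number 8 percentage points higher from compound 1 to compound 4 (within the scatter), and with compound 2 going against any steady trend, chain length gives no regular progression across these compounds. Among the compounds shown here, nothing available gives a reason for the one step beyond the scatter.

Still open, from the compounds shown here alone, is whether a longer chain than that of compound 4 would continue the shift or whether much shorter chains would behave differently. Also open, going by these compounds, is what an amine or a carboxylic acid at the far end of the chain would do at this position.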